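The source may hold more compounds than are shown below. What is called first, only, known or untested is meant among the compounds shown, and "the series" means these compounds.

Compound 3 `O=C(CCCl)Nc1ccc(SCC(=O)Nc2ccc(Br)cn2)cc1` stands highest of the two plain numbers in a functional assay on HeLa cells (Homo sapiens) for antiproliferative activity, read by MTT assay, with a stated time of 48 h; a higher number here means a weaker inhibitor, a lower number a stronger inhibitor: compound 3 gives 15600 nM, and compound 1 `O=C(CCl)Nc1ccc(SCC(=O)Nc2ccc(Br)cn2)cc1` gives 2100 nM, the step being a 7.4-fold higher number from compound 1 to compound 3 (0.87 log units; beyond the scatter). Compound 2 `O=C(CCl)Nc1ccc(SCC(=O)Nc2ccc(Cl)cc2)cc1` reports only a limit, > 80000 nM. Compound 4 `O=C(CCCl)Nc1ccc(SCC(=O)Nc2ccc(Cl)cc2)cc1` is still to be measured; it differs from compound 3 by 4-chlorophenyl in place of 5-bromopyridin-2-yl on an amide-type nitrogen. The same exchange has been seen once, as an at least 38-fold higher number from compound 1 to compound 2 (1.58 log units; beyond the scatter), ending at the limit of > 80000 nM in this assay, at which 1 of the 3 values shown sits. A step of that size from compound 3 would also run past that limit, so compound 4 is expected to give a higher number in this assay, with a 9.6-fold higher number from compound 3 to compound 4 (0.98 log units; beyond the scatter) the estimated step and a limit the most likely report. The estimate for compound 4 is 150000 nM, within 40000 nM to 600000 nM.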

Compound 4, half-maximal inhibitory concentration: > 80000 nM
Compound 4 ended at the assay's limit; the forecaster's own chance of this, stated with the estimate: 85%; the middle value lies beyond the limit too.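

The exchange of 5-bromopyridin-2-yl for 4-chlorophenyl on the amide-type nitrogen also weakens the chloromethyl-extended compound in this assay, with an at least 5.1-fold higher number from compound 3 to compound 4 (0.70 log units; beyond the scatter). The direction therefore holds on two cores, but the sizes cannot be compared: the same change on two cores in this assay, an at least 38-fold higher number (1.58 log units; beyond the scatter) from compound 1 to compound 2 and an at least 5.1-fold higher number (0.70 log units; beyond the scatter) from compound 3 to compound 4; the limit leaves it open whether they differ Compound 2 and compound 4 both end at a limit, and the step between them cannot be read: the limit of > 80000 nM in this assay, at which 2 of the 4 values shown sit.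

The compounds shown leave open whether the ring nitrogen or the halogen carries the difference, as the exchange alters both. A 4-bromophenyl or 5-chloropyridin-2-yl group on that nitrogen would separate the two.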